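Methoxymethyl on a second ring nitrogen: expected effect on HeLa

The source may hold more compounds than are shown below. What is called first, only, known or untested is meant among the compounds shown, and "the series" means these compounds.

Measured compounds:
compound 1, `O=c1cc(CC(COCc2ccccc2)COCc2ccccc2)[nH]c(=O)[nH]1`, in a functional assay on HeLa cells (Homo sapiens) for antiproliferative activity, read by MTT assay, with a stated time of 72 h; a lower number here means a stronger inhibitor, a higher number a weaker inhibitor: > 100000 nM
compound 2, `COCn1c(CC(COCc2ccccc2)COCc2ccccc2)cc(=O)[nH]c1=O`, in this assay: > 100000 nM
compound 3, `COCn1c(=O)[nH]c(CC(COCc2ccccc2)COCc2ccccc2)c(C)c1=O`, in this assay: 17000 nM

The value of compound 1 in this assay, > 100000 nM, is a limit of the assay and not a number. The value of compound 2 in this assay, > 100000 nM, is likewise a limit. The change between them is methoxymethyl in place of hydrogen on an aromatic nitrogen. Both values sit at the limit of > 100000 nM in this assay, at which 2 of the 3 values shown sit, so the pair yields a step that the two limits leave unreadable from compound 1 to compound 2. For the measured compounds named here, compound 3 gives 17000 nM in this assay, the only number among the three. The difference between the core of compound 1 and the core of compound 3 is not broken down here.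

Compound 4, `COCn1c(CC(COCc2ccccc2)COCc2ccccc2)c(C)c(=O)n(COC)c1=O`, is not yet measured. It differs from compound 3 by methoxymethyl in place of hydrogen on an aromatic nitrogen. Around the place, the change in compound 4 is additionally meta to a methoxymethyl group (3 heavy atoms) and meta to a methyl group (1 heavy atom), which is not so for the change from compound 1 to compound 2; it is the same kind of change, not the same. The measured pair gives no readable size for this kind of step: a step that the two limits leave unreadable from compound 1 to compound 2. The expectation for compound 4 therefore rests on compound 3 at 17000 nM, with wide bounds. The step from compound 3 to compound 4 in this assay is expected to be a 1.5-fold higher number from compound 3 to compound 4 (0.17 log units; within the scatter). Compound 4 is estimated at 25000 nM, between 8000 nM and 100000 nM.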

Compound 4, half-maximal inhibitory concentration: 300 nM
Compound 4: middle estimate off by 83-fold (1.92 log units), on the high side; measured number below the stated range.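

In this assay, methoxymethyl in place of hydrogen on an aromatic nitrogen comes with a 57-fold lower number from compound 3 to compound 4 (1.75 log units; beyond the scatter), so on the core of compound 3 this change has a large effect on the measured number. The same kind of change on the core of compound 1 cannot be read, because the values of compound 1 and compound 2 are both limits of the assay and not numbers: the limit of > 100000 nM in this assay, at which 2 of the 4 values shown sit. The series therefore offers one readable size for this change, on one core, where the new methoxymethyl group is meta to a methoxymethyl group and meta to a methyl group; the data do not show that a step of this size carries over to a core lacking either neighbouring group, nor do they exclude it.

As far as these compounds go, it remains open whether the step belongs to methoxymethyl itself, or whether an ethyl group or a longer chain ending in an amine on the same nitrogen would give a similar number. From the compounds shown here alone, it also remains open how much the methyl group on the ring contributes to the size of the step.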